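The source may hold more compounds than are shown below. What is called first, only, known or untested is meant among the compounds shown, and "the series" means these compounds.

Of the compounds shown here, three from this series have been measured in a functional assay on HEK293 cells for negative allosteric modulation of metabotropic glutamate receptor 5 (Homo sapiens), read by calcium flux, with a stated time of 20 min (a lower number here means a stronger inhibitor, a higher number a weaker inhibitor), a test for blocking a glutamate receptor. Compound 1 `Cc1cccnc1-c1cc2n(n1)CCN(C(=O)c1ccccc1)C2` returns only the limit of the test, > 10000 nM (the limit of > 10000 nM in this assay, at which 1 of the 3 values shown sits). Compound 2 `O=C(c1ccccc1)N1CCn2nc(-c3ccc(F)cn3)cc2C1` gives 164 nM, and compound 3 `O=C(c1ccccc1)N1CCn2nc(-c3ccc(Cl)cn3)cc2C1` gives 201 nM. Among the two numbers shown, compound 2 has the lowest, with compound 3 beside it a 1.2-fold higher number from compound 2 to compound 3 (0.09 log units; within the scatter); the two cannot be told apart. The steps that carry a large change, an at least 60-fold lower number from compound 1 to compound 2 (1.78 log units; beyond the scatter) and an at least 49-fold lower number from compound 1 to compound 3 (1.69 log units; beyond the scatter), both alter the pyridine ring attached to the shared core.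

Compound 4 `N#Cc1cccc(C(=O)N2CCn3nc(-c4ccc(F)cn4)cc3C2)c1` is not yet measured. It differs from compound 2 in another part of the molecule: cyano in place of hydrogen on an aromatic carbon, so the benzoyl side becomes a 3-cyanophenyl carbonyl. For the measured compounds named here, none of the measured steps touches this ring; the only step on an unchanged pyridine, from compound 2 to compound 3, stays within the scatter. No measured evidence therefore points to a change in either direction, and the expected step in this assay is a 1.0-fold higher number from compound 2 to compound 4 (0.02 log units; within the scatter), that is, none beyond the scatter. Compound 4 is expected to give about 170 nM, between 50 nM and 600 nM.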

Compound 4, half-maximal inhibitory concentration: > 10000 nM
Compound 4: only a limit was reported; the forecaster's own chance of this, stated with the estimate: 5%; middle value at least 58-fold (1.76 log units) away from the limit.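

In this assay, for the compounds shown here, the earlier compounds showed large steps only at the pyridine ring, whereas this result shows that the phenyl ring of the benzoyl group is just as able to decide the outcome: an at least 60-fold higher number from compound 2 to compound 4 (1.78 log units; beyond the scatter). Compound 4 reads > 10000 nM, which is a limit of the test and not a number. So a single cyano group of 2 heavy atoms, placed on an aromatic carbon meta to a large group, is enough to take a compound with a measurable value to the limit, and changes on either side of the shared core can now have this outcome: the limit of > 10000 nM in this assay, at which 2 of the 4 values shown sit.

Still open, on these data alone, is whether this loss belongs to the cyano group itself or would follow from any group at this place, such as a fluoro, a methyl or a methoxy group, and whether a cyano group elsewhere on the phenyl ring would do the same. Also open is whether the change would act in the same way on compound 3, as the cyano group is shown here only with the 5-fluoropyridin-2-yl group.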